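Fluoro Added to the Inactive Pyridyl Analogue

A few compounds are considered here, and "the series" means these few. Any claim that something is new, unique, unknown or untested is made for them only; others in the source may bear on it.

Compound 1 `O=c1c(Cn2ccnc2)coc2cc(F)ccc12` gives 86.9 nM in an assay on V79MZh cells for inhibition of cytochrome P450 11B1, mitochondrial (Homo sapiens), with a stated time of 6 h; a lower number here means a stronger inhibitor, a higher number a weaker inhibitor. Compound 2 `O=c1c(Cc2cccnc2)coc2ccccc12` differs from compound 1 in two places, so the two values alone show a wide gap. In this assay compound 2 reaches only a limit, > 10000 nM. That limit is the limit of > 10000 nM in this assay, at which 1 of the 2 values shown sits. Compound 3 `O=c1c(Cc2cccnc2)coc2cc(F)ccc12` carries the change (fluoro in place of hydrogen on an aromatic carbon). Going by the values given here, no measured step with this change alone is at hand; a shift no larger than the scatter is expected in this assay, a number no higher from compound 2 to compound 3 (the limit leaves the size open). Compound 3 is therefore expected to give about 10000 nM, between 3000 nM and 30000 nM, most probably again reported only as a limit.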

Compound 3, half-maximal inhibitory concentration: > 10000 nM
Compound 3 ended at the assay's limit (the forecaster's own chance of this, stated with the estimate: 70%); the middle value lies on the limit itself.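

The wide gap between compound 1 and compound 2 spanned two places, whereas compound 3 leaves a single change, pyridin-3-yl in place of 1H-imidazol-1-yl on the saturated chain carbon, and in this assay that change gives an at least 110-fold higher number from compound 1 to compound 3 (2.06 log units; beyond the scatter). Compound 3 gives > 10000 nM, which is a limit of the assay. With both compound 2 and compound 3 at limits, the step for fluoro in place of hydrogen cannot be read.

Still open, going by these compounds, is what fluoro contributes when 1H-imidazol-1-yl occupies the chain carbon. Also open, on these data alone, is whether another group there, such as a 1H-1,2,4-triazol-1-yl or an amine, would stay near the value of compound 1.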